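Methylating the phenol of compound 2 in the kinase assay

The compounds below may be only part of what the source reports. "The series", "measured", "known", "first", "only" and "open" are said of these compounds alone.

Compound 1, `Cn1cc(/C=C2\C(=O)Nc3ccc(S(N)(=O)=O)cc32)c2ccccc21`: 112%
Compound 2, `CN(C)S(=O)(=O)c1ccc2c(c1)/C(=C/c1cn(C)c3ccc(O)cc13)C(=O)N2`: 120%

Two compounds have so far been examined in an assay on isolated protein for inhibition of homeodomain-interacting protein kinase 2 (Homo sapiens), tested at 0.1 uM; on this read-out higher numbers stand for a weaker effect at the one concentration tested and lower numbers for a stronger effect. In this assay compound 1 gives 112%, and compound 2 gives 120%. Compound 2 carries the highest of the two numbers, yet the nearest number, that of compound 1, lies within the scatter of it, so the two cannot be told apart; both sit at the weak end of the read-out.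

Compound 3, `COc1ccc2c(c1)c(/C=C1\C(=O)Nc3ccc(S(=O)(=O)N(C)C)cc31)cn2C`, has not yet been measured in this assay. It differs from compound 2 in a single place: methyl in place of hydrogen on an oxygen on an aromatic ring. Among the measured compounds shown here, no step between measured compounds is available, so there is nothing to set the size of this change against. Because compound 2 gives 120% in this assay, the expected step of a number 6 percentage points lower from compound 2 to compound 3 (within the scatter) is none beyond the scatter. For compound 3 the estimate in this assay is 114%, with a range from 96% to 132%.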

Compound 3, a percentage reported as activity, at one concentration (the size of the read-out at that concentration, not a potency): 109%
Compound 3: the middle estimate sits 5 percentage points above what was measured; low and high end bracket the measured number.
By their numbers in this assay, from the lowest: compounds 3, 1 and 2 (each within the scatter of the next, the first and the last beyond it).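

Going from hydroxy to methoxy gives the first readable step in this assay, and that step is a number 11 percentage points lower from compound 2 to compound 3 (beyond the scatter) and so moves the number towards a stronger effect. It shows that methyl can take the place of hydrogen on this oxygen on an aromatic ring without the number rising, which the earlier comparison of two compounds within the scatter of each other could not show, though compound 3 at 109% still stands at the weak end of the read-out. Nothing measured here accounts for this modest change.

On these data alone, whether a longer chain on this oxygen, such as ethoxy, or an amine in place of the methoxy would carry the number further towards a stronger effect remains open. Among the compounds shown here, with only this one step in hand, it also stays unknown whether the same exchange of hydrogen for methyl would move the number by a similar amount on a compound that differs elsewhere in the shared core.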